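Triazolyl glucoside series: naphthalenyl replaces phenyl on alkene

The source may hold more compounds than are shown below. What is called first, only, known or untested is meant among the compounds shown, and "the series" means these compounds.

Measured so far:
Compound 1 `CC(=O)OC[C@H]1O[C@@H](n2cc(Cn3cc([N+](=O)[O-])c4ccccc43)nn2)[C@H](OC(C)=O)[C@@H](OC(C)=O)[C@@H]1OC(C)=O` — in a functional assay on MCF7 cells (Homo sapiens) for cytotoxicity, read by sulforhodamine B assay, with a stated time of 48 h (a higher number here means a weaker inhibitor, a lower number a stronger inhibitor), compound 1 gives > 200000 nM, which is a limit of the assay and not a number.
Compound 2 `CC(=O)OC[C@H]1O[C@@H](n2cc(CN3C(=O)/C(=C\c4ccccc4)c4ccccc43)nn2)[C@H](OC(C)=O)[C@@H](OC(C)=O)[C@@H]1OC(C)=O` — in this assay compound 2 gives 24300 nM.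
Compound 3 `CC(=O)OC[C@H]1O[C@@H](n2cc(CN3C(=O)/C(=C/c4ccccc4)c4ccccc43)nn2)[C@H](OC(C)=O)[C@@H](OC(C)=O)[C@@H]1OC(C)=O` — in this assay compound 3 gives 30200 nM.

Compound 3 and compound 2 therefore sit within the scatter of each other; the only further entry, compound 1, is a limit. Among the measured compounds shown here, the one measured step, a 1.2-fold higher number from compound 2 to compound 3 (0.09 log units; within the scatter), is explained by the fact that compounds 2 and 3 differ only in the configuration as drawn and shows that the configuration of the double bond does not move the number beyond the scatter.

Compound 4 `CC(=O)OC[C@H]1O[C@@H](n2cc(CN3C(=O)/C(=C/c4ccc5ccccc5c4)c4ccccc43)nn2)[C@H](OC(C)=O)[C@@H](OC(C)=O)[C@@H]1OC(C)=O` keeps the core of compound 3 and carries naphthalen-2-yl in place of phenyl on a double-bonded chain carbon bound to a double-bonded ring carbon. For the measured compounds named here, no measured step touches this part of the molecule: the step from compound 2 to compound 3 concerns the drawing of the double bond only, and compound 1 carries a different substituent altogether and sits at a limit. There is thus no measured basis for a step beyond the scatter in either direction in this assay.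

The expectation for compound 4 is a step of a 1.0-fold lower number from compound 3 to compound 4 (0.00 log units; within the scatter), essentially none. Compound 4 is estimated at 30000 nM, with a range from 10000 nM to 100000 nM.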

Compound 4, half-maximal inhibitory concentration: 32700 nM
The estimate for compound 4 lay 1.1-fold (0.04 log units) below the measured number, and the stated range covers the measured number.
By their numbers in this assay, from the lowest: compounds 2, 3 and 4 (each within the scatter of the next). At a limit, above all of these: compound 1.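

Among the compounds shown here, compound 4 is the first compound to alter the group itself on the double-bonded chain carbon bound to a double-bonded ring carbon, rather than only the drawing of the double bond. In this assay, naphthalen-2-yl in place of phenyl gives a 1.1-fold higher number from compound 3 to compound 4 (0.03 log units; within the scatter), so at this place a group of 10 heavy atoms with 2 six-membered aromatic rings and one of 6 heavy atoms with a single such ring leave the two numbers within the scatter of each other, and the larger carbon-only aromatic group is tolerated in this read-out without any gain. Nothing at hand accounts for this insensitivity to the size of the aromatic group.

On these data alone, the groups at this place are all aromatic and of carbon only, so it remains open whether an amine, a carboxylic acid or a longer chain there would move the number beyond the scatter. As far as these compounds go, it also remains open whether naphthalen-2-yl would give the same picture with the double bond drawn the other way, as a single pair cannot settle that.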